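The compounds below may be only part of what the source reports. "The series", "measured", "known", "first", "only" and "open" are said of these compounds alone.

In a functional assay on B16 cells (Mus musculus) for cytotoxicity, read by MTT assay, with a stated time of 48 h (on this read-out lower numbers stand for stronger inhibition and higher numbers for weaker inhibition), compound 1 `C#CCNC(=O)c1cn(CCOC(C)=O)nn1` reaches only a limit, > 100000 nM. Compound 2 `C#Cc1cccc(NC(=O)c2cn(CCOC(C)=O)nn2)c1` gives a true number, 25100 nM. Compound 3 `C#Cc1ccc(NC(=O)c2cn(Cc3ccccc3)nn2)cc1` also reaches only a limit, > 100000 nM, so it has no number of its own; this is the limit of > 100000 nM in this assay, at which 2 of the 3 values shown sit. Compound 4 `C#Cc1ccc(NC(=O)c2cn(CC(=O)OCC)nn2)cc1` differs from compound 3 by ethoxycarbonyl in place of phenyl on a saturated chain carbon bound to an aromatic nitrogen, with ethoxycarbonyl in place of phenyl on a saturated chain carbon bound to an aromatic nitrogen. Within the data shown here, no measured pair isolates this change. Among the measured compounds shown here, compound 2, whose chain also holds an ester, gives 25100 nM, the only number so far. On that basis, a modest move towards stronger inhibition is expected, an estimated at least 2.0-fold lower number from compound 3 to compound 4 (0.30 log units; that floor lies within the scatter). For compound 4 the estimated value is 50000 nM, with an expected range from 15000 nM to 150000 nM.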

Compound 4, half-maximal inhibitory concentration: > 100000 nM
Compound 4: only a limit was reported (the forecaster's own chance of this, stated with the estimate: 45%); middle value at least 2.0-fold (0.30 log units) from the limit.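

Compound 3 and compound 4 both reach only a limit, so no step can be read between them: the limit of > 100000 nM in this assay, at which 3 of the 4 values shown sit. On these data alone, whether ethoxycarbonyl in place of phenyl changes inhibition at all remains open.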